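A few compounds are considered here, and "the series" means these few. Any claim that something is new, unique, unknown or untested is made for them only; others in the source may bear on it.

The measured compounds and their values:

- Compound 1, `Cc1cc(-c2ccc(O)cc2)c2ncc(CSCCc3ccccc3)n2c1`: 20 ug/mL
- Compound 2, `Cc1cc(-c2ccsc2)c2ncc(CSCCc3ccccc3)n2c1`: 100 ug/mL
- Compound 3, `COc1cccc(-c2cc(C)cn3c(CSCCc4ccccc4)cnc23)c1`: 100 ug/mL

In an ADME assay on HEL cells (Homo sapiens) for cytotoxicity, with a stated time of 3 days (on this read-out higher numbers stand for lower toxicity in this test and lower numbers for higher toxicity in this test), compound 3 gives 100 ug/mL. It stands level with compound 2, and these two share the highest number of the three; compound 1 lies furthest from compound 3, the step being a 5.0-fold higher number from compound 1 to compound 3 (0.70 log units; beyond the scatter). The step of no change at the digits printed from compound 2 to compound 3 (within the scatter) shows that exchanging one aromatic group for another on this position left the read-out unchanged.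

Compound 4, `Cc1cc(-c2cccs2)c2ncc(CSCCc3ccccc3)n2c1`, has not yet been measured. It differs from compound 3 in one place: thiophen-2-yl in place of 3-methoxyphenyl on an aromatic carbon. Within the data shown here, two measured steps bear on this change. The step of a 5.0-fold higher number from compound 1 to compound 2 (0.70 log units; beyond the scatter) shows that a thiophen-3-yl at this position gave a higher number than a 4-hydroxyphenyl, and the step of no change at the digits printed from compound 2 to compound 3 (within the scatter) shows that a 3-methoxyphenyl and a thiophen-3-yl gave the same number. Since a thiophen-2-yl is close in kind to the thiophen-3-yl of compound 2, no step beyond the scatter is expected in this assay from compound 3 to compound 4, that is no change at the digits printed from compound 3 to compound 4 (within the scatter) is expected. Compound 4 is therefore estimated at 100 ug/mL, in the range 50 ug/mL to 200 ug/mL.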

Compound 4, minimum cytotoxic concentration: 100 ug/mL
Compound 4: the middle estimate sits on the measured number at the digits printed, and the stated range covers the measured number.
By their numbers in this assay, from the lowest: compound 1; then compounds 2, 3 and 4 (each within the scatter of the next).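

The thiophene ring can be attached through either of its two positions without any effect on the read-out in this assay (no change at the digits printed from compound 2 to compound 4 (within the scatter)). A smaller group also leaves the number in place, since five heavy atoms in a five-membered aromatic ring with one hetero atom stand in for the eight heavy atoms of 3-methoxyphenyl (no change at the digits printed from compound 3 to compound 4 (within the scatter)). Compound 1 now lies apart from three different aryl groups rather than two (a 5.0-fold higher number from compound 1 to compound 4 (0.70 log units; beyond the scatter)), so among these compounds only the 4-hydroxyphenyl group gives the lower number, and nothing given here explains this.

The compounds shown leave open whether that lower number follows from the hydroxyl group itself or from where it sits on the phenyl ring, a question that a 3-hydroxyphenyl or a 4-methoxyphenyl group would address. They also leave open how this position would read with an amine or a carboxylic acid on the aromatic ring, since every group here is a neutral aromatic ring with no such function.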